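The source may hold more compounds than are shown below. What is called first, only, known or untested is meant among the compounds shown, and "the series" means these compounds.

Working notes. Compound 1 `Cc1cc(N2CC[C@@H](C)[C@@H](N(C)c3ncnc4[nH]ccc34)C2)n2nc(SCC3CCCCC3)nc2n1` is the only numbered point in a toxicity assay on GES1 cells (Homo sapiens) for inhibition, read by MTT assay, with a stated time of 72 h (a lower number here means a stronger inhibitor, a higher number a weaker inhibitor), where compound 1 gives 98200 nM. Compound 2 `C[C@@H]1CCN(c2cc(-c3ccccc3)nc3ncnn23)C[C@@H]1N(C)c1ncnc2[nH]ccc12` returns only a limit in this assay, > 100000 nM, which is the limit of > 100000 nM in this assay, at which 1 of the 2 values shown sits. Compound 3 `Cc1cc(N2CC[C@@H](C)[C@@H](N(C)c3ncnc4[nH]ccc34)C2)n2nc(SCC3CC3)nc2n1` differs from compound 1 by cyclopropyl in place of cyclohexyl on a saturated chain carbon bound to a sulfur. Among the compounds with values here, no measured step between compounds is available; the change is weighed against compound 1 alone. The expected step is a 1.1-fold higher number from compound 1 to compound 3 (0.05 log units; within the scatter), none beyond the scatter, with a higher number, if any, as the likelier direction. Compound 3 is thus estimated at 110000 nM, between 50000 nM and 250000 nM.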

Compound 3, half-maximal inhibitory concentration: 27900 nM
For compound 3 the middle estimate is 3.9-fold (0.60 log units) above the measured one; measured number outside the range, below it.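

In this assay, the ring on the saturated chain carbon bound to a sulfur proves to matter: cyclopropyl in place of cyclohexyl gives a 3.5-fold lower number from compound 1 to compound 3 (0.55 log units; beyond the scatter). Within the data shown here, this is the only single-place change available, and it shows greater toxicity to these cells with the smaller ring. Compound 2 gives a limit and not a number: the limit of > 100000 nM in this assay, at which 1 of the 3 values shown sits.

One step cannot establish a trend with ring size. From the compounds shown here alone, whether the number would follow the same direction with cyclopentyl, an open-chain isobutyl or a piperidine ring in this place remains open.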